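Replacing Fluoro with Dimethylamino on the Aniline Ring

A few compounds are considered here, and "the series" means these few. Any claim that something is new, unique, unknown or untested is made for them only; others in the source may bear on it.

Of the compounds shown here, three sharing one core have been tested in a functional assay on NCI-H1975 cells (Homo sapiens) for antiproliferative activity, read by MTT assay, with a stated time of 72 h; on this read-out higher numbers stand for weaker inhibition and lower numbers for stronger inhibition. Compound 1 `COc1cc(F)c(NC(=O)c2ccncc2)cc1Nc1nccc(-c2cn(C)c3ccccc23)n1` gives 4370 nM, compound 2 `COc1cc(F)c(NC(=O)c2ncccn2)cc1Nc1nccc(-c2cn(C)c3ccccc23)n1` gives 13500 nM, and compound 3 `COc1cc(F)c(NC(=O)c2nccn2C)cc1Nc1nccc(-c2cn(C)c3ccccc23)n1` gives 10600 nM, which places compound 3 second highest of the three: the step of a 1.3-fold lower number from compound 2 to compound 3 (0.11 log units; within the scatter) lies within the scatter, whereas a 2.4-fold higher number from compound 1 to compound 3 (0.38 log units; beyond the scatter) lies beyond it. Compound 4 `COc1cc(N(C)C)c(NC(=O)c2nccn2C)cc1Nc1nccc(-c2cn(C)c3ccccc23)n1` differs from compound 3 in one place: dimethylamino in place of fluoro on an aromatic carbon. Going by the values given here, none of the measured steps bears on this change; both a 3.1-fold higher number from compound 1 to compound 2 (0.49 log units; beyond the scatter) and a 2.4-fold higher number from compound 1 to compound 3 (0.38 log units; beyond the scatter) alter the group on the carbonyl carbon instead, so the data give no guide for the ring substituent. Compound 4 is therefore expected to stay close to compound 3, a 1.1-fold lower number from compound 3 to compound 4 (0.03 log units; within the scatter), with wide uncertainty. Compound 4 is estimated at 10000 nM, between 3000 nM and 35000 nM.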

Compound 4, half-maximal inhibitory concentration: 2880 nM
Estimate against measurement, compound 4: 3.5-fold (0.54 log units) above, and the stated range ends above it.
By their numbers in this assay, from the lowest: compounds 4 and 1 (each within the scatter of the next); then compounds 3 and 2 (each within the scatter of the next).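

In this assay, the position ortho to the ((1-methyl-1H-imidazol-2-yl)carbonyl)amino group responds to its substituent: dimethylamino in place of fluoro gives a 3.7-fold lower number from compound 3 to compound 4 (0.57 log units; beyond the scatter) and so moves toward stronger inhibition, beyond the scatter. Going by these compounds alone, the earlier steps changed only the group on the carbonyl carbon, so this is the first measured effect at this ring position. No available evidence accounts for the step.

From the compounds shown here alone, whether methylamino or morpholine would act alike remains open. So does whether dimethylamino gives a similar step alongside the pyridin-4-yl group of compound 1.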